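Shifting the amino group on the anilino ring of compound 2

The source may hold more compounds than are shown below. What is called first, only, known or untested is meant among the compounds shown, and "the series" means these compounds.

Compound 1 is `Oc1ccc(Nc2nc(-c3cccc(F)c3)nc3ccc(F)cc23)cc1`; in a functional assay on U2OS cells (Homo sapiens) for cytotoxicity, read by MTT assay, with a stated time of 48 h (on this read-out higher numbers stand for weaker inhibition and lower numbers for stronger inhibition), compound 1 gives > 50000 nM, which is a limit of the assay rather than a number.
Compound 2 is `Nc1cccc(Nc2nc(-c3cccc(F)c3)nc3ccc(F)cc23)c1`; in this assay compound 2 gives 49700 nM.

Within the data shown here, compound 2 therefore holds the only number among the two measured compounds, the other value being a limit, and that number lies close to the limit itself. Compound 3 is `Nc1ccccc1Nc1nc(-c2cccc(F)c2)nc2ccc(F)cc12`. It differs from compound 2 by 2-aminophenyl in place of 3-aminophenyl on a nitrogen on an aromatic ring, the same atoms joined differently; cut one bond further out, the change reads (3-aminophenyl)amino to (2-aminophenyl)amino. Among the measured compounds shown here, the one measured step at this position is a number no higher from compound 1 to compound 2 (the limit leaves the size open), whose size cannot be read because one end of it is the limit of > 50000 nM in this assay, at which 1 of the 2 values shown sits. Nothing measured suggests that relocating the amino group on this ring moves the read-out beyond the scatter, so compound 3 is expected to stay near compound 2, with an estimated step of a 1.1-fold lower number from compound 2 to compound 3 (0.04 log units; within the scatter). Compound 3 is thus estimated at 45000 nM, between 12000 nM and 120000 nM, with a fair chance that this assay again reports only a limit.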

Compound 3, half-maximal inhibitory concentration: 37900 nM
The estimate for compound 3 lay 1.2-fold (0.07 log units) above the measured number; low and high end bracket the measured number.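

Among these compounds, compound 3 gives the first step at this position in this assay with a number at both ends: a 1.3-fold lower number from compound 2 to compound 3 (0.12 log units; within the scatter). Moving the amino group from 3-aminophenyl to 2-aminophenyl on a nitrogen on an aromatic ring therefore produces no difference that this read-out can separate from repeated measurement, so the two isomers stand level here, and the earlier pair could not show this because one of its ends was a limit. The comparison with the 4-hydroxyphenyl compound gives an at least 1.3-fold lower number from compound 1 to compound 3 (0.12 log units; that floor lies within the scatter), a floor only, which leaves the true size of that change unknown, and compound 1 remains a limit and not a number: the limit of > 50000 nM in this assay, at which 1 of the 3 values shown sits.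

The compounds shown leave open whether the 4-aminophenyl isomer would also stay at this level, and whether a different group on this ring, such as a carboxylic acid, a methoxy group or a longer aminoalkyl chain, would bring the number clearly down. They also leave open whether the lack of a separable step between the two amino isomers would hold with a different group in place of the 3-fluorophenyl on the shared core.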